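Removing the acetyl from an aminotriazole core pair

The compounds below may be only part of what the source reports. "The series", "measured", "known", "first", "only" and "open" are said of these compounds alone.

Compound 1 `COc1ncc(-c2ccc3nc(NC(C)=O)nn3c2)cc1NS(=O)(=O)c1ccc(Cl)cc1` and compound 2 `COc1ncc(-c2ccc3nc(N)nn3c2)cc1NS(=O)(=O)c1ccc(Cl)cc1` share one core, while compound 3 `COc1ncc(-c2ccn3nc(NC(C)=O)nc3c2)cc1NS(=O)(=O)c1ccc(F)cc1` and compound 4 `COc1ncc(-c2ccn3nc(N)nc3c2)cc1NS(=O)(=O)c1ccc(F)cc1` share another; the difference between the two cores is not broken down here. In a functional assay on MCF7 cells (Homo sapiens) for antiproliferative activity, read by MTT assay, with a stated time of 48 h (on this read-out lower numbers stand for stronger inhibition and higher numbers for weaker inhibition), compound 1 gives 2010 nM. Compound 2 gives 1820 nM in this assay. Compound 3 gives 1730 nM in this assay, and this number sits alongside those of compound 1 and compound 2 without any of the gaps reaching beyond the scatter.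

The change from compound 1 to compound 2 is hydrogen in place of acetyl on a nitrogen on an aromatic ring. This change gave a 1.1-fold lower number from compound 1 to compound 2 (0.04 log units; within the scatter). Compound 4 is made from compound 3 by hydrogen in place of acetyl on a nitrogen on an aromatic ring, the same change at the same kind of place, with the same neighbour around the nitrogen. Compound 4 has not been measured in this assay.

Because the earlier step was a 1.1-fold lower number from compound 1 to compound 2 (0.04 log units; within the scatter), the step from compound 3 to compound 4 is expected to be small, a 1.1-fold lower number from compound 3 to compound 4 (0.03 log units; within the scatter). Compound 4 is estimated to give about 1600 nM in this assay. Among the compounds with values here, compound 4 is expected to fall between 800 nM and 3200 nM, a range that rests on only one earlier example of this change.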

Compound 4, half-maximal inhibitory concentration: 920 nM
Estimate against measurement, compound 4: 1.7-fold (0.24 log units) above, within the range that was stated.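

In this assay, replacing acetyl with hydrogen on the nitrogen of the second core gave a 1.9-fold lower number from compound 3 to compound 4 (0.27 log units; within the scatter), and this step cannot be told apart from the earlier one on the first core: the same change on two cores in this assay, a 1.1-fold lower number (0.04 log units; within the scatter) from compound 1 to compound 2 and a 1.9-fold lower number (0.27 log units; within the scatter) from compound 3 to compound 4, 1.7-fold (0.23 log units) apart, within the scatter of two such steps Within these two pairs, then, acetamido to amino carries from one core to the other without a detectable difference in size, and neither step stands clear of the usual variation between repeated measurements. Within the data shown here, this does not show that the change has a real effect on either core, or that it would behave the same way on further cores, since only two examples are at hand and the pairs differ in more than the core, with chlorine in compound 1 and compound 2 and fluorine in compound 3 and compound 4.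

The compounds shown leave open what a longer acyl chain such as propanoyl, or a methyl group, would do on that nitrogen in this assay. They also leave open how the step would read with a bromine or a methoxy group in place of the halogen.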